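The source may report more compounds than this note shows. Statements on the series, on what has been measured and on what is new or still open speak of the compounds shown alone.

In a functional assay (aorta) with Rattus norvegicus as the target (on this read-out higher numbers stand for weaker inhibition and lower numbers for stronger inhibition), compound 1 `CC1(C)Oc2ccc(C#N)cc2[C@@H](/N=C(\NC#N)Nc2ccc(Cl)cc2)[C@@H]1O`, which carries 4-chlorophenyl, gives 1800 nM. Compound 2 `CC1(C)Oc2ccc(C#N)cc2[C@@H](/N=C(\NC#N)Nc2cccc(C(=O)O)c2)[C@@H]1O` gives > 100000 nM, and this is a limit of the assay, not a number. Compound 3 `Cc1cccc(N/C(=N/[C@@H]2c3cc(C#N)ccc3OC(C)(C)[C@H]2O)NC#N)c1` departs from compound 2 by methyl in place of carboxy on an aromatic carbon, meta to a large group. Among the compounds with values here, only one measured step bears on this change. It is an at least 55-fold higher number from compound 1 to compound 2 (1.74 log units; beyond the scatter), a large step beyond the scatter that came with 3-carboxyphenyl in place of 4-chlorophenyl on an amine nitrogen. Compound 3 no longer has the carboxy group, so given that step a large move to a lower number, meaning stronger inhibition, is expected in this assay. The expected change is an at least 33-fold lower number from compound 2 to compound 3 (1.52 log units; beyond the scatter). Compound 3 is estimated at 3000 nM, with an expected range of 800 nM to 15000 nM.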

Compound 3, half-maximal inhibitory concentration: 1000 nM
Estimate against measurement, compound 3: 3.0-fold (0.48 log units) above; the range from low to high includes it.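

In this assay, methyl at the same ring position as the carboxy gives an at least 100-fold lower number from compound 2 to compound 3 (2.00 log units; beyond the scatter), which ties the loss seen with compound 2 to the carboxy group and not to the 3-substituted phenyl pattern as such. The 3-methylphenyl and 4-chlorophenyl groups cannot be told apart on this read-out, with a 1.8-fold lower number from compound 1 to compound 3 (0.26 log units; within the scatter), so a substituent at this position does not in itself weaken inhibition. The value of compound 2 is a limit of the assay and not a number: the limit of > 100000 nM in this assay, at which 1 of the 3 values shown sits.

The compounds shown leave open whether a carboxamide, a methyl ester or an amine at this position would behave like the carboxylic acid or like methyl. They also leave open how a chloro group at this position would compare with methyl.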